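The source may report more compounds than this note shows. Statements on the series, on what has been measured and on what is new or still open speak of the compounds shown alone.

Measured so far:
compound 1, `O=C(O)COc1ccc(F)cc1C1CCCCC1`: 446 nM
compound 2, `O=C(O)CCCOc1ccc(Cl)cc1C1CCCCC1`: 1990 nM

In an assay on CHO cells for displacement of a labelled ligand from prostaglandin D2 receptor 2 (Homo sapiens) (on this read-out lower numbers stand for stronger inhibition and higher numbers for weaker inhibition), compound 1 gives 446 nM, the lower of the two numbers; compound 2 gives 1990 nM, a higher number that lies beyond the usual scatter. Compound 3, `Cc1ccc(OCC(=O)O)c(C2CCCCC2)c1`, is not yet measured. It differs from compound 1 by methyl in place of fluoro on an aromatic carbon. Among the compounds with values here, no measured pair shows this exchange, so nothing here tells how it acts. Lacking such a comparison, the expected step is a 1.1-fold higher number from compound 1 to compound 3 (0.05 log units; within the scatter), not clearly beyond the scatter in either direction. Compound 3 is therefore estimated at 500 nM, within 150 nM to 1600 nM.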

Compound 3, inhibition constant: 353 nM
Compound 3: middle estimate off by 1.4-fold (0.15 log units), on the high side, within the range that was stated.
By their numbers in this assay, from the lowest: compounds 3 and 1 (each within the scatter of the next); then compound 2.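

In this assay, putting methyl in place of fluoro on this aromatic carbon, para to the carboxymethoxy group, gives a 1.3-fold lower number from compound 1 to compound 3 (0.10 log units; within the scatter), so compound 1 and compound 3 cannot be told apart. At this position, then, these two groups of 1 heavy atom each are interchangeable as far as this read-out can show. No measurement here explains this match. Still open, as far as these compounds go, is how larger or quite different groups at this position, such as methoxy, trifluoromethyl or an amine, would read in this assay. A hydrogen there would also show whether any group is needed at all.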